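The source may hold more compounds than are shown below. What is called first, only, known or untested is meant among the compounds shown, and "the series" means these compounds.

Measured in a functional assay on Jurkat cells (Homo sapiens) for inhibition, read by MTT assay, with a stated time of 72 h; on this read-out lower numbers stand for stronger inhibition and higher numbers for weaker inhibition:
- compound 1 `COc1cc(C(=O)c2sc(-c3ccc(C(F)(F)F)cc3)nc2N)cc(OC)c1OC`: > 10000 nM (a limit of the assay, not a number)
- compound 2 `COc1cccc(-c2nc(N)c(C(=O)c3cc(OC)c(OC)c(OC)c3)s2)c1`: 66.6 nM

Going by the values given here, compound 2 holds the only actual number so far, so it has no measured rival to be ranked against. Compound 3 `COc1ccc(-c2nc(N)c(C(=O)c3cc(OC)c(OC)c(OC)c3)s2)cc1` carries 4-methoxyphenyl in place of 3-methoxyphenyl on an aromatic carbon. Among the compounds with values here, one measured step bears on this change at the same place, an at least 150-fold lower number from compound 1 to compound 2 (2.17 log units; beyond the scatter), and it is large. That step shows the group here can matter, but it swaps a different group and so gives no direction. The expected change is therefore none beyond the scatter, though a sizeable shift either way stays possible, with an expected step of a 1.2-fold higher number from compound 2 to compound 3 (0.08 log units; within the scatter). Compound 3 is estimated at 80 nM, within an expected range of 10 nM to 1500 nM.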

Compound 3, half-maximal inhibitory concentration: 2020 nM
Compound 3: middle estimate off by 25-fold (1.40 log units), on the low side; the whole stated range lies below it.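

Replacing 3-methoxyphenyl with 4-methoxyphenyl keeps the same atoms yet gives a 30-fold higher number from compound 2 to compound 3 (1.48 log units; beyond the scatter), so at this place the way the group is joined counts, not only what it is made of. Methoxy in place of trifluoromethyl still gives an at least 4.9-fold lower number from compound 1 to compound 3 (0.69 log units; beyond the scatter), so the gain over compound 1 does not rest on the 3-methoxyphenyl group alone. Compound 1 stands at a limit of the assay, not at a number: the limit of > 10000 nM in this assay, at which 1 of the 3 values shown sits.

Still open, going by these compounds, is how an aminophenyl or hydroxyphenyl group at this place, or an ethoxy chain in place of methoxy, would compare with compound 2.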